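A few compounds are considered here, and "the series" means these few. Any claim that something is new, unique, unknown or untested is made for them only; others in the source may bear on it.

Compound 3 `CC(C(=O)NCc1ccc(C(F)(F)F)cc1N1CCC(C)(C)CC1)c1ccc(NS(C)(=O)=O)c(F)c1` stands second highest of three numbers in an assay on CHO cells for antagonist activity at transient receptor potential cation channel subfamily V member 1 (Homo sapiens), read by FLIPR (a higher number here means a weaker inhibitor, a lower number a stronger inhibitor), where compound 3 gives 1.3 nM. Compound 1 `CCCN(CCC)c1cc(C(F)(F)F)ccc1CNC(=O)C(C)c1ccc(NS(C)(=O)=O)c(F)c1` gives 0.3 nM, and compound 2 `CC(C(=O)NCc1ccc(C(F)(F)F)cc1N1CCCCCCC1)c1ccc(NS(C)(=O)=O)c(F)c1` gives 2.8 nM. Compound 4 `CC(C)COc1cc(C(F)(F)F)ccc1CNC(=O)C(C)c1ccc(NS(C)(=O)=O)c(F)c1` carries isobutoxy in place of 4,4-dimethylpiperidin-1-yl on an aromatic carbon. Two measured steps already touch this position: a 4.3-fold higher number from compound 1 to compound 3 (0.64 log units; beyond the scatter) and a 2.2-fold lower number from compound 2 to compound 3 (0.33 log units; beyond the scatter), so exchanging the group here has so far shifted the number only modestly in either direction. Returning to an open chain resembles the move back toward compound 1, which gives 0.3 nM, yet the new group has no ring and fewer atoms than any group tried, so only a modest change is expected: a 1.2-fold higher number from compound 3 to compound 4 (0.06 log units; within the scatter). Compound 4 is expected to give about 1.5 nM, within 0.4 nM to 6 nM.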

Compound 4, inhibition constant: 0.8 nM
Beside the measured number, compound 4's estimate is 1.9-fold (0.27 log units) above it; the measured number falls inside the stated range.
By their numbers in this assay, from the lowest: compound 1; then compounds 4 and 3 (each within the scatter of the next); then compound 2.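

With isobutoxy, the position accepts a group joined through oxygen rather than nitrogen, with no ring and fewer heavy atoms, and this assay shows a 1.6-fold lower number from compound 3 to compound 4 (0.21 log units; within the scatter) and a 3.5-fold lower number from compound 2 to compound 4 (0.54 log units; beyond the scatter). Against the open-chain dipropylamino group, isobutoxy gives a 2.7-fold higher number from compound 1 to compound 4 (0.43 log units; beyond the scatter), so compound 1 keeps the lowest number of the four. Nothing measured here explains these shifts. The compounds shown do not separate the effect of the linking atom from that of chain size. From the compounds shown here alone, how a diethylamino group or a cyclohexyloxy group would compare remains open.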